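A Trifluoromethyl Step Repeated on a Second Core

The compounds below may be only part of what the source reports. "The series", "measured", "known", "first", "only" and "open" are said of these compounds alone.

Compound 1 `Oc1cccc2[nH]c(-c3ccc(-c4ccc(-c5ccc(F)cc5)cc4)cc3)nc12` is the starting point. In a functional assay on DWD cells (Homo sapiens) for inhibition, read by sulforhodamine B assay (a higher number here means a weaker inhibitor of growth, a lower number a stronger inhibitor of growth), compound 1 gives 22200 nM. Compound 2 `Oc1cccc2[nH]c(-c3ccc(-c4ccc(-c5ccc(C(F)(F)F)cc5)cc4)cc3)nc12` shares its core and differs only by trifluoromethyl in place of fluoro on an aromatic carbon; in this assay compound 2 gives 3180 nM. The step of a 7.0-fold lower number from compound 1 to compound 2 (0.84 log units; beyond the scatter). Compound 3 `Cc1ccc2[nH]c(-c3ccc(-c4ccc(-c5ccc(F)cc5)cc4)cc3)nc2c1` has a different core; the difference between the cores of compound 1 and compound 3 is not broken down here. In this assay compound 3 gives 33100 nM, a number within the scatter of compound 1 and clearly apart from compound 2. Compound 4 `Cc1ccc2[nH]c(-c3ccc(-c4ccc(-c5ccc(C(F)(F)F)cc5)cc4)cc3)nc2c1` has not yet been measured. It stands to compound 3 as compound 2 stands to compound 1, with trifluoromethyl in place of fluoro on an aromatic carbon, the same change made at the same place on the other core. Because the earlier change gave a 7.0-fold lower number from compound 1 to compound 2 (0.84 log units; beyond the scatter), a step of similar size is expected for compound 4, namely a 7.0-fold lower number from compound 3 to compound 4 (0.85 log units; beyond the scatter). Compound 4 is therefore estimated at 4700 nM, expected to fall between 2000 nM and 12000 nM.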

Compound 4, concentration for 50% growth inhibition: 38200 nM
The estimate for compound 4 lay 8.1-fold (0.91 log units) below the measured number, outside the stated range (above it).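

On the second core, the trifluoromethyl change gave no step beyond the scatter in this assay, with a 1.2-fold higher number from compound 3 to compound 4 (0.06 log units; within the scatter), so the drop seen on the core of compound 1 did not carry over: the same change on two cores in this assay, a 7.0-fold lower number (0.84 log units; beyond the scatter) from compound 1 to compound 2 and a 1.2-fold higher number (0.06 log units; within the scatter) from compound 3 to compound 4, 8.1-fold (0.91 log units) apart, beyond the scatter of two such steps

With trifluoromethyl held constant, the two cores stand clearly apart, with a 12-fold higher number from compound 2 to compound 4 (1.08 log units; beyond the scatter), where 5-methyl-1H-benzimidazol-2-yl takes the place of 4-hydroxy-1H-benzimidazol-2-yl. This shows that, in these two pairs, the size of the step depends on the core, but it does not show which feature of the cores is responsible, and one pair on each core sets no rule for other cores in the series.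

The compounds shown leave open whether the hydroxy group, the methyl group or some other part of the core difference governs the step. They also leave open how a chlorine atom, a nitrile or an amine in place of fluoro would behave on each core.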